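A dichlorophenyl sulfonamide weighed against three weak analogues

A few compounds are considered here, and "the series" means these few. Any claim that something is new, unique, unknown or untested is made for them only; others in the source may bear on it.

The measured compounds, all tested in an assay on cells for inhibition of HSP60/HSP10 (Homo sapiens), with a stated time of 60 min (a higher number here means a weaker inhibitor, a lower number a stronger inhibitor), are these:

compound 1 `COc1ccc(S(=O)(=O)Nc2ccc(-c3nc4ccccc4o3)cc2)cc1`, giving > 100000 nM, a limit of the assay rather than a number;
compound 2 `CCc1ccc(S(=O)(=O)Nc2ccc3oc(-c4ccccc4)nc3c2)cc1`, giving > 100000 nM, again a limit of the assay;
compound 3 `O=S(=O)(Nc1ccc2oc(-c3ccccc3)nc2c1)c1ccc(Cl)s1`, giving 70000 nM.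

Compound 1 therefore stands at the edge of what this assay reports: it is one of the two compounds that return only a limit, as the limit of > 100000 nM in this assay, at which 2 of the 3 values shown sit, records. Compound 4 `O=S(=O)(Nc1ccc(-c2nc3ccccc3o2)cc1)c1ccc(Cl)c(Cl)c1` differs from compound 1 in one place, (3,4-dichlorophenyl in place of 4-methoxyphenyl on a sulfonyl sulfur). For the measured compounds named here, the only measured step that bears on this change is a swap of the group on the sulfonyl sulfur, an at least 1.4-fold lower number from compound 2 to compound 3 (0.15 log units; that floor lies within the scatter), and that step is small, its floor lying within the scatter. A swap of the sulfonyl aryl group has thus not moved the numbers in this assay beyond the scatter, so compound 4 is expected to remain weak, with the step of an at least 1.1-fold lower number from compound 1 to compound 4 (0.04 log units; that floor lies within the scatter) estimated as no more than a modest change. Compound 4 is estimated at 90000 nM, with a range from 30000 nM to 300000 nM, and a real chance that this assay again returns only a limit.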

Compound 4, half-maximal inhibitory concentration: 25000 nM
Estimate against measurement, compound 4: 3.6-fold (0.56 log units) above; measured number outside the range, below it.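

On the sulfonyl sulfur of the core of compound 1, 3,4-dichlorophenyl in place of 4-methoxyphenyl gives an at least 4.0-fold lower number from compound 1 to compound 4 (0.60 log units; beyond the scatter) in this assay. The group on this sulfur can therefore move the number beyond the scatter, which the earlier swap on the other core, an at least 1.4-fold lower number from compound 2 to compound 3 (0.15 log units; that floor lies within the scatter), did not show. The size of the new step is only a floor, as the value of compound 1 is a limit and not a number: the limit of > 100000 nM in this assay, at which 2 of the 4 values shown sit.

The compounds shown leave open whether both chlorines are needed, or whether a phenyl group carrying a single chlorine, a trifluoromethyl group or a carboxylic acid would give a similar step. They also leave open whether 3,4-dichlorophenyl would give such a step on the core of compound 2.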